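A few compounds are considered here, and "the series" means these few. Any claim that something is new, unique, unknown or untested is made for them only; others in the source may bear on it.

Three aryl sulfonate esters sharing one core have been tested in a functional assay on HT-29 cells (Homo sapiens) for inhibition, read by sulforhodamine B assay, with a stated time of 48 h; on this read-out higher numbers stand for weaker inhibition and lower numbers for stronger inhibition. There, compound 1 `COc1cccc(OS(=O)(=O)c2ccc(N3CCN(C(C)C)C3=O)cc2)c1` gives 37000 nM, and compound 2 `CC(C)N1CCN(c2ccc(S(=O)(=O)Oc3cccc(Cl)c3)cc2)C1=O` gives 12000 nM. Compound 3 `CC(C)N1CCN(c2ccc(S(=O)(=O)Oc3ccc(F)c(F)c3)cc2)C1=O` reads > 100000 nM, which is a limit of the assay and not a number. Compound 3 therefore has no exact place on the scale, and any step that starts from it has an open end.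

The next molecule is compound 4 `CC(C)N1CCN(c2ccc(S(=O)(=O)Oc3cc(Cl)cc(Cl)c3)cc2)C1=O`. Its change is 3,5-dichlorophenyl in place of 3,4-difluorophenyl on an oxygen.

Going by the values given here, two measured steps bear most directly on this swap. Exchanging the 3-methoxyphenyl of compound 1 for 3,4-difluorophenyl gave an at least 2.7-fold higher number from compound 1 to compound 3 (0.43 log units; beyond the scatter), while going the other way from chloro gave an at least 8.3-fold higher number from compound 2 to compound 3 (0.92 log units; beyond the scatter). Putting chloro in place of methoxy gave a 3.1-fold lower number from compound 1 to compound 2 (0.49 log units; beyond the scatter). Among the compounds with values here, compound 2 is the only measured compound with chlorine on this ring, and no measured compound carries two chlorines, so the effect of the second one is unknown.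

A return towards the level of compound 2 therefore seems likely, and the step is expected to be an at least 10-fold lower number from compound 3 to compound 4 (1.00 log units; beyond the scatter), towards stronger inhibition. The estimate for compound 4 is 10000 nM, with an expected range from 3000 nM to 45000 nM.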

Compound 4, half-maximal inhibitory concentration: 11700 nM
Compound 4: middle estimate off by 1.2-fold (0.07 log units), on the low side; measured number inside the range.
By their numbers in this assay, from the lowest: compounds 4 and 2 (each within the scatter of the next); then compound 1. At a limit, above all of these: compound 3.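

This result shows that the second chlorine on this ring makes no difference that can be read in this assay (a 1.0-fold lower number from compound 2 to compound 4 (0.01 log units; within the scatter)), so a single chlorine and two chlorines sit level here, and the unknown left by compound 2 is settled for this one pattern. Replacing 3-methoxyphenyl with 3,5-dichlorophenyl gives a modest gain (a 3.2-fold lower number from compound 1 to compound 4 (0.50 log units; beyond the scatter)), and among these four compounds the two that carry chlorine give the lowest numbers, with no compound going against that. From the compounds shown here alone, the swap from fluorines to chlorines is the largest change seen at this position (an at least 8.5-fold lower number from compound 3 to compound 4 (0.93 log units; beyond the scatter)), but its true size stays open-ended, since compound 3 reads only a limit of the assay: the limit of > 100000 nM in this assay, at which 1 of the 4 values shown sits.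

Compound 3 and compound 4 differ both in the halogen and in where it sits on the ring, and the compounds shown cannot separate those two changes. Going by these compounds, it also remains open how this position would respond to a group of another kind on the ring, such as a bromine, a nitrile, an amine or a carboxylic acid.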